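The source may report more compounds than this note shows. Statements on the series, on what has been measured and on what is new or still open speak of the compounds shown alone.

Measured compounds and their values:
Compound 1 `COc1cc2c(Oc3c(F)cc(NC(=O)NN4C(=O)CSC4c4c(F)cccc4F)cc3F)ccnc2cc1OCCCN1CCCC1` — in a functional assay on A549 cells (Homo sapiens) for antiproliferative activity, read by MTT assay, with a stated time of 72 h (a higher number here means a weaker inhibitor, a lower number a stronger inhibitor), compound 1 gives 560 nM.
Compound 2 `COc1cc2c(Oc3c(F)cc(NC(=O)NN4C(=O)C(C)SC4c4c(F)cccc4F)cc3F)ccnc2cc1OCCCN1CCCC1` — in this assay compound 2 gives 830 nM.
Compound 3 `COc1cc2c(Oc3c(F)cc(NC(=O)NN4C(=O)CSC4c4c(F)cccc4F)cc3F)ccnc2cc1OCCCN1CCc2sccc2C1` — for compound 3 this assay reports only a limit, > 20000 nM.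

All three share one core and differ only at two places. The step of a 1.5-fold higher number from compound 1 to compound 2 (0.17 log units; within the scatter) shows that a methyl on the saturated ring carbon leaves the number essentially where it was. The other step, an at least 35-fold higher number from compound 1 to compound 3 (1.55 log units; beyond the scatter), is the large one, and it puts compound 3 at the limit of > 20000 nM in this assay, at which 1 of the 3 values shown sits, so that its number is known only as a limit and not as a measured value.

Compound 4 `COc1cc2c(Oc3c(F)cc(NC(=O)NN4C(=O)CSC4c4c(F)cccc4F)cc3F)ccnc2cc1OCCCN1CCN(C)CC1` differs from compound 3 by a group of 7 heavy atoms (5 carbon, 2 nitrogen; one six-membered non-aromatic ring with 2 hetero atoms) in place of a group of 9 heavy atoms (7 carbon, 1 nitrogen, 1 sulfur; one five-membered aromatic ring with 1 hetero atom, one six-membered non-aromatic ring with 1 hetero atom), on a saturated chain carbon, three bonds along the chain from an oxygen on an aromatic ring. This is the same position at which the step of an at least 35-fold higher number from compound 1 to compound 3 (1.55 log units; beyond the scatter) was observed, and the group entering in compound 4 is a single six-membered ring, closer in size and shape to the five-membered ring of compound 1 than to the bicyclic group of compound 3. The change is therefore expected to undo most of that step: the step from compound 3 to compound 4 is estimated as an at least 22-fold lower number from compound 3 to compound 4 (1.34 log units; beyond the scatter), downward and beyond the scatter. Compound 4 is expected to give 900 nM in this assay, with a range from 250 nM to 5000 nM.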

Compound 4, half-maximal inhibitory concentration: 510 nM
The estimate for compound 4 lay 1.8-fold (0.25 log units) above the measured number; the measured number falls inside the stated range.
By their numbers in this assay, from the lowest: compounds 4, 1 and 2 (each within the scatter of the next). At a limit, above all of these: compound 3.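

In this assay, among these compounds, the earlier compounds showed only that one replacement of pyrrolidin-1-yl at this place, on a saturated chain carbon, three bonds along the chain from an oxygen on an aromatic ring, carries a heavy cost. With 4-methylpiperazin-1-yl as the entering group the result is a 1.1-fold lower number from compound 1 to compound 4 (0.04 log units; within the scatter), so the position accepts a second group with a single non-aromatic ring, and the large step of an at least 39-fold lower number from compound 3 to compound 4 (1.59 log units; beyond the scatter) points to the particular group with the five-membered aromatic ring rather than to any change at this place. The value of compound 3 is a limit, so that step has a bound and not an exact size: the limit of > 20000 nM in this assay, at which 1 of the 4 values shown sits.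

The compounds shown leave open whether the loss seen with compound 3 goes with its five-membered aromatic ring and sulfur or with the larger group as a whole. They also leave open how a morpholin-4-yl or piperidin-1-yl group at this place, or a longer chain carrying 4-methylpiperazin-1-yl, would read in this assay.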